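Methyl for Methoxy on the Benzyl Ring of Compound 1

The compounds below may be only part of what the source reports. "The series", "measured", "known", "first", "only" and "open" are said of these compounds alone.

For the measured compounds named here, compound 1 `COc1ccc(Cn2cc[nH]c2=S)cc1OC` gives 339000 nM in an assay on isolated protein for inhibition of Dopamine beta-hydroxylase (Rattus norvegicus) (a lower number here means a stronger inhibitor, a higher number a weaker inhibitor), the highest of the three numbers measured so far. Compound 2 `S=c1[nH]ccn1Cc1ccc(Br)cc1` gives 115000 nM, a lower number than compound 1 by a margin beyond the usual scatter. Compound 3 `S=c1[nH]ccn1Cc1cccc(Cl)c1Cl` gives 52500 nM, the lowest of the three, and its gap to compound 1 is also beyond the scatter. No two of these compounds differ in only one place, so no single step can be read from them; all that is shown is that the two halogenated compounds sit below compound 1, which carries two methoxy groups.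

Compound 4 `COc1ccc(Cn2cc[nH]c2=S)cc1C` is the next compound to be measured in this assay. It differs from compound 1 as follows: methyl in place of methoxy on an aromatic carbon The change is small in heavy-atom count and removes one hydrogen-bond acceptor from the ring substituents.

Within this series the compounds without a methoxy group, compound 2 and compound 3, give the lower numbers, so the step is expected to be downward but modest, a 1.7-fold lower number from compound 1 to compound 4 (0.23 log units; within the scatter), with a real chance that it stays within the scatter. Compound 4 is estimated at 200000 nM, with a range from 80000 nM to 500000 nM.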

Compound 4, half-maximal inhibitory concentration: 69200 nM
Compound 4: middle estimate off by 2.9-fold (0.46 log units), on the high side; the measured number lies below the stated range.
By their numbers in this assay, from the lowest: compounds 3, 4 and 2 (each within the scatter of the next, the first and the last beyond it); then compound 1.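

In this assay, methyl in place of methoxy on the aromatic carbon ortho to a methoxy group and meta to a group of 7 heavy atoms gives a 4.9-fold lower number from compound 1 to compound 4 (0.69 log units; beyond the scatter), a step beyond the scatter. For the compounds shown here, this is the first change that can be read at a single place, and it shows that this position alone can move the number, with the other methoxy group and the shared core unchanged. It also shows that a methoxy group at this position is not required for activity in this assay, while the data give no reason for the direction of the step, as nothing measured on these compounds bears on it.

As far as these compounds go, one replacement at one position gives no trend, so it remains open whether the step depends on methyl itself or would also appear with a hydroxyl group, an amine, a carboxylic acid or a longer chain such as ethyl at the same carbon. Also open, from the compounds shown here alone, is whether replacing the remaining methoxy group of compound 4 with methyl would move the number in the same direction.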